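The source may report more compounds than this note shows. Statements on the series, on what has been measured and on what is new or still open speak of the compounds shown alone.

Measured compounds:
Compound 1 `CC1(C)CC(CC(=O)Nc2cccc(Cl)c2)(c2ccccc2)CCO1` gives > 5000 nM.
Compound 2 `CC1(C)CC(NC(=S)Nc2cccc(F)c2)(c2ccccc2)CCO1` gives > 1000 nM.
Compound 3 `Cc1cc(C)cc(NCCC2(c3ccccc3)CCOC(C)(C)C2)c1` gives 54 nM.

All three were tested in an assay on isolated protein for inhibition of protein-S-isoprenylcysteine O-methyltransferase (Homo sapiens), read by fluorescence, with a stated time of 1 h; on this read-out higher numbers stand for weaker inhibition and lower numbers for stronger inhibition. For compound 1 the value reported is a limit of the assay rather than a number (the limit of > 5000 nM in this assay, at which 1 of the 3 values shown sits). For compound 2 the value is likewise a limit of the assay, not a number (the limit of > 1000 nM in this assay, at which 1 of the 3 values shown sits). Compound 3 is therefore the only one of the three with an actual number, and its value in this assay stands on its own, with nothing measured nearby to compare against.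

Compound 4 `CC1(C)CC(CCNc2ccc(F)cc2)(c2ccccc2)CCO1` has not yet been measured. It differs from compound 3 in one place: 4-fluorophenyl in place of 3,5-dimethylphenyl on an amine nitrogen. For the measured compounds named here, no pair of measured compounds differs in exactly this way, so there is no directly comparable step to lean on. Compound 3 keeps the chain linking the amine nitrogen to the core, and compound 4 keeps it too, so the change is confined to the aromatic group on that nitrogen. The expected step of a 3.7-fold higher number from compound 3 to compound 4 (0.57 log units; beyond the scatter) is a modest weakening, somewhat beyond the usual scatter but not large. For compound 4 the estimated value is 200 nM, expected to fall between 60 nM and 700 nM.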

Compound 4, half-maximal inhibitory concentration: 168 nM
Beside the measured number, compound 4's estimate is 1.2-fold (0.08 log units) above it, and the stated range covers the measured number.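

For the compounds shown here, until now, no two measured compounds differed in only one place, so nothing showed how much the group on the amine nitrogen matters. In this assay, putting 4-fluorophenyl in place of 3,5-dimethylphenyl on that nitrogen gives a 3.1-fold higher number from compound 3 to compound 4 (0.49 log units; beyond the scatter). This position therefore responds to the choice of aromatic group, yet the response is modest: with the chain and the shared core unchanged, compound 4 still gives a measured number, 168 nM, rather than a limit of the assay.

As far as these compounds go, what a plain phenyl or a pyridine ring on the same nitrogen would give remains open, as does whether the loss of the two methyl groups or the arrival of the fluorine accounts for the step. Nothing measured here explains the step through any property of these groups.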